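The source may report more compounds than this note shows. Statements on the series, on what has been measured and on what is new or still open speak of the compounds shown alone.

Of the compounds shown here, three on a shared core have been measured in an ADME assay on HEK293 cells (Homo sapiens) for cytotoxicity, read by CellTiter-Glo, with a stated time of 72 h; a lower number here means that less compound is needed, a higher number that more compound is needed for the effect. Compound 1 `CC1=C2CC(C)(C)/C=C/C/C(C)=C\C3=C[C@H](C)C[C@]3(O2)C1=O` gives 26000 nM. Compound 2 `CC1=C2CC(C)(C)/C=C/[C@H](O)/C(C)=C\C3=C[C@H](C)C[C@]3(O2)C1=O`, with a hydroxy group on a saturated ring carbon, gives 26000 nM. Compound 3 `CC(=O)O[C@H]1/C=C/C(C)(C)CC2=C(C)C(=O)[C@]3(C[C@@H](C)C=C3/C=C\1C)O2`, with acetoxy in that place, gives 26000 nM. Compound 2 therefore stands level with both of the others.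

Compound 4 `CC1=C2CC(C)(C)/C=C/[C@@H](O)/C(C)=C\C3=C[C@H](C)C[C@]3(O2)C1=O` is a stereoisomer of compound 2: the two compounds have the same atoms and bonds and differ only in configuration as drawn: 1 of 5 stereo elements differ; a stereocentre at a saturated ring carbon is drawn S in compound 2 and R in compound 4. Within the data shown here, no measured step tests a change of configuration directly, so the evidence is indirect. The nearest steps concern the group at that carbon, and this assay shows no change at the digits printed from compound 1 to compound 2 (within the scatter) and no change at the digits printed from compound 1 to compound 3 (within the scatter). Acetylating the hydroxy group gave the same picture, with no change at the digits printed from compound 2 to compound 3 (within the scatter).

If neither removing nor capping the hydroxy group moved the reading, inverting it is not expected to do so either. The estimated outcome is no change at the digits printed from compound 2 to compound 4 (within the scatter), which means no step beyond the scatter is expected. For compound 4 the estimated value is 26000 nM, with an expected range of 14000 nM to 45000 nM.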

Compound 4, half-maximal effective concentration: 26000 nM
For compound 4 middle estimate and measured number coincide at the digits printed, within the range that was stated.
By their numbers in this assay, from the lowest: compounds 1, 2, 3 and 4 (each within the scatter of the next).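

In this assay, the pair gives the first direct test of configuration at this saturated ring carbon, and inverting the hydroxy group leaves the reading where it was, with no change at the digits printed from compound 2 to compound 4 (within the scatter). The second configuration also reads the same as hydrogen at that carbon, with no change at the digits printed from compound 1 to compound 4 (within the scatter), so both drawn forms of the hydroxy group now match the compound without it. The comparison isolates configuration alone: the fact that compounds 2 and 4 differ only in the configuration as drawn.

On these data alone, this position has so far carried only hydrogen, hydroxy and acetoxy, so whether an amine or a carboxylic acid at this carbon would move the reading remains open. With all four compounds at the same number, the compounds shown also leave open which parts of the shared core, if any, the reading depends on.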